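The source may report more compounds than this note shows. Statements on the series, on what has been measured and on what is new or still open speak of the compounds shown alone.

For the measured compounds named here, in a functional assay on CCRF-CEM cells (Homo sapiens) (a lower number here means a stronger inhibitor, a higher number a weaker inhibitor), three compounds built on one shared core have numbers so far. Compound 1 `Nc1ncnc2c1ncn2C[C@@H]1C[C@H](CO)c2ccccc21` gives 24 ug/mL, compound 2 `CC(C)Nc1ncnc2c1ncn2C[C@@H]1C[C@H](CO)c2ccccc21` gives 24 ug/mL, and compound 3 `OC[C@H]1C[C@@H](Cn2cnc3c(-c4ccc(Cl)cc4)ncnc32)c2ccccc21` gives 0.63 ug/mL, the lowest of the three and so the strongest inhibitor of this small set. Compound 4 `CCCNc1ncnc2c1ncn2C[C@@H]1C[C@H](CO)c2ccccc21` has not been measured yet. It differs from compound 3 by having propylamino in place of 4-chlorophenyl on an aromatic carbon.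

Going by the values given here, three measured steps bear on this change. Bringing in 4-chlorophenyl at that carbon gave large steps: a 38-fold lower number from compound 1 to compound 3 (1.58 log units; beyond the scatter), and also a 38-fold lower number from compound 2 to compound 3 (1.58 log units; beyond the scatter). The new change runs the opposite way. Changing the group on the nitrogen made no clear difference, as no change at the digits printed from compound 1 to compound 2 (within the scatter) shows, although no straight propyl chain has been tested. A large step back up is therefore expected, to a weaker inhibitor: a 38-fold higher number from compound 3 to compound 4 (1.58 log units; beyond the scatter). For compound 4 the estimated value is 24 ug/mL, with an expected range from 10 ug/mL to 50 ug/mL.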

Compound 4, half-maximal inhibitory concentration: 24 ug/mL
The estimate for compound 4 equals the measured number at the digits printed; measured number inside the range.
By their numbers in this assay, from the lowest: compound 3; then compounds 1, 2 and 4 (each within the scatter of the next).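

In this assay the straight propyl chain on the nitrogen gives the same reading as the isopropyl chain (no change at the digits printed from compound 2 to compound 4 (within the scatter)) and as the bare amino group (no change at the digits printed from compound 1 to compound 4 (within the scatter)). Hydrogen, isopropyl and propyl on this nitrogen therefore cannot be told apart here, so branching of this chain shows no effect in this set. The large gap to 4-chlorophenyl at the same aromatic carbon (a 38-fold higher number from compound 3 to compound 4 (1.58 log units; beyond the scatter)) now extends to a third amine, and no measurement here explains it.

A plain phenyl group at this carbon would show whether the ring alone carries the gap or whether the chlorine is needed. A longer chain such as hexyl, or a benzylamino group, would test whether any amine here can move away from this level.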